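The compounds below may be only part of what the source reports. "The series", "measured", "known", "first", "only" and "open" are said of these compounds alone.

Three carbamates on a shared core have been measured in a functional assay on CHO-K1 cells for agonist activity at Glucose-dependent insulinotropic receptor (Homo sapiens), read by a luciferase reporter, with a stated time of 5 h; a higher number here means that more compound is needed for the effect, a lower number that less compound is needed. Compound 1 `CC(C)OC(=O)N1CCC(Oc2ncnc3c2CCN3c2ccc(S(C)(=O)=O)cc2F)CC1` gives 50.1 nM, compound 2 `COC(=O)N1CCC(Oc2ncnc3c2CCN3c2ccc(S(C)(=O)=O)cc2F)CC1` gives 316 nM, and compound 3 `CCCOC(=O)N1CCC(Oc2ncnc3c2CCN3c2ccc(S(C)(=O)=O)cc2F)CC1` gives 79.4 nM. Compound 3 therefore holds the second highest of the three numbers: it sits near compound 1, since a 1.6-fold higher number from compound 1 to compound 3 (0.20 log units; within the scatter), and further from compound 2, since a 4.0-fold lower number from compound 2 to compound 3 (0.60 log units; beyond the scatter).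

The next compound, compound 4 `CCCCOC(=O)N1CCC(Oc2ncnc3c2CCN3c2ccc(S(C)(=O)=O)cc2F)CC1`, differs from compound 3 only in this way: methyl in place of hydrogen on a saturated chain carbon, three bonds along the chain from an oxygen next to a carbonyl group. Two of the measured steps bear on it. The step from compound 2 to compound 3 lengthened the same chain by two carbons and lowered the number beyond the scatter, as a 4.0-fold lower number from compound 2 to compound 3 (0.60 log units; beyond the scatter) shows, while the step from compound 1 to compound 3, a change of branching at the same chain without a change in carbon count, stayed within the scatter, as a 1.6-fold higher number from compound 1 to compound 3 (0.20 log units; within the scatter) shows. The gain from lengthening was already taken between compound 2 and compound 3, so one further carbon is expected to bring at most a small step in this assay, if any, and a 1.3-fold lower number from compound 3 to compound 4 (0.10 log units; within the scatter) is what is expected. Compound 4 is accordingly estimated at 63 nM, with a likely range from 25 nM to 160 nM.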

Compound 4, half-maximal effective concentration: 50.1 nM
Compound 4: middle estimate off by 1.3-fold (0.10 log units), on the high side; measured number inside the range.
By their numbers in this assay, from the lowest: compounds 1, 4 and 3 (each within the scatter of the next); then compound 2.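

In this assay, the methyl that turns propyl into butyl, on a saturated chain carbon, three bonds along the chain from an oxygen next to a carbonyl group, gives a 1.6-fold lower number from compound 3 to compound 4 (0.20 log units; within the scatter) and so leaves the read-out inside the usual scatter at this position. The larger comparisons show that the separation from the methyl carbamate persists at this chain length, with a 6.3-fold lower number from compound 2 to compound 4 (0.80 log units; beyond the scatter), while the straight butyl chain and the branched isopropyl group cannot be told apart, with no change at the digits printed from compound 1 to compound 4 (within the scatter); compounds 1, 3 and 4 thus form a flat stretch within the scatter of one another, and compound 2 alone stands apart from it. No supporting evidence is available to explain this flat stretch.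

The compounds shown leave open whether the flat stretch continues to a longer chain such as pentyl or hexyl, or whether it ends there. They also leave open how a tert-butyl or cyclopropylmethyl group on the same oxygen would compare, and what an amide or urea in place of the carbamate would do.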